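From 3-hydroxyphenyl to 4-aminophenyl

The source may hold more compounds than are shown below. What is called first, only, known or untested is meant among the compounds shown, and "the series" means these compounds.

Measured in a functional assay on U-251 cells (Homo sapiens) for antiproliferative activity, read by MTT assay, with a stated time of 48 h; on this read-out lower numbers stand for stronger inhibition and higher numbers for weaker inhibition:
- compound 1 `COc1cc(-c2cccc3nc(-c4cccc(F)c4)oc23)cc(OC)c1OC`: 2900 nM
- compound 2 `COc1cc(-c2cccc3nc(-c4ccc(Br)cc4)oc23)cc(OC)c1OC`: > 25000 nM, a limit of the assay and not a number
- compound 3 `COc1cc(-c2cccc3nc(-c4cccc(O)c4)oc23)cc(OC)c1OC`: 5500 nM

Compound 3 stands level with compound 1, as the swap of fluoro for hydroxy gave a 1.9-fold higher number from compound 1 to compound 3 (0.28 log units; within the scatter). Compound 4 `COc1cc(-c2cccc3nc(-c4ccc(N)cc4)oc23)cc(OC)c1OC` has 4-aminophenyl in place of 3-hydroxyphenyl on an aromatic carbon. The closest guide is the 4-bromophenyl group, which gave an at least 8.6-fold higher number from compound 1 to compound 2 (0.93 log units; beyond the scatter) and, when replaced by 3-hydroxyphenyl, an at least 4.5-fold lower number from compound 2 to compound 3 (0.65 log units; beyond the scatter). The 4-aminophenyl is a different group, so only part of that loss is expected to carry over, pointing to a higher number in this assay. The expected change is a 2.0-fold higher number from compound 3 to compound 4 (0.30 log units; within the scatter). For compound 4 the estimate is 11000 nM, with an expected range from 3000 nM to 25000 nM.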

Compound 4, half-maximal inhibitory concentration: 1040 nM
Beside the measured number, compound 4's estimate is 11-fold (1.02 log units) above it; measured number below the stated range.
By their numbers in this assay, from the lowest: compound 4; then compounds 1 and 3 (each within the scatter of the next). At a limit, above all of these: compound 2.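

In this assay, 4-aminophenyl on this carbon gives the lowest number of the compounds shown, with a 5.3-fold lower number from compound 3 to compound 4 (0.72 log units; beyond the scatter) and a 2.8-fold lower number from compound 1 to compound 4 (0.45 log units; beyond the scatter). With the ring kept and only its substituent changed, amino in place of bromo gives an at least 24-fold lower number from compound 2 to compound 4 (1.38 log units; beyond the scatter), so the group on this phenyl ring can decide between weak and stronger inhibition. The value of compound 2 is a limit and not a number: the limit of > 25000 nM in this assay, at which 1 of the 4 values shown sits.

Compound 3 and compound 4 differ in both the group and its place on the ring, so the two effects remain unseparated. A 3-aminophenyl or a 4-hydroxyphenyl group would tell them apart.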